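Exchanging the group on the aromatic nitrogen once more

The source may hold more compounds than are shown below. What is called first, only, known or untested is meant among the compounds shown, and "the series" means these compounds.

Going by the values given here, compound 2 `N=S1(=O)CC(Nc2nonc2/C(=N/O)Nc2ccc(F)c(Br)c2)C1` is one of two compounds measured so far in an assay on isolated protein for inhibition of Indoleamine 2,3-dioxygenase 1 (Homo sapiens), read by fluorescence, with a stated time of 60 min (a higher number here means a weaker inhibitor, a lower number a stronger inhibitor), where compound 2 gives 208 nM. Among the compounds with values here, its only neighbour, compound 1 `NNc1nonc1/C(=N/O)Nc1ccc(F)c(Br)c1`, gives 108 nM in this assay, and the step of a 1.9-fold higher number from compound 1 to compound 2 (0.28 log units; within the scatter) lies within the scatter, so the two numbers are indistinguishable. Compound 3 `O=S(=O)(CCNc1nonc1/C(=N/O)Nc1ccc(F)c(Br)c1)NO` has not yet been measured. It differs from compound 2 by a group of 7 heavy atoms (2 carbon, 1 nitrogen, 3 oxygen, 1 sulfur; no ring) in place of a group of 6 heavy atoms (3 carbon, 1 nitrogen, 1 oxygen, 1 sulfur; one four-membered non-aromatic ring with 1 hetero atom), on a nitrogen on an aromatic ring. Within the data shown here, the one measured step that bears on this change is a 1.9-fold higher number from compound 1 to compound 2 (0.28 log units; within the scatter), since it also exchanged the group on that same nitrogen and left the number within the scatter. Among the measured compounds shown here, as no measured step points in either direction, the expected step from compound 2 to compound 3 is a 1.0-fold lower number from compound 2 to compound 3 (0.02 log units; within the scatter), none beyond the scatter. Compound 3 is therefore estimated at 200 nM, within a range from 70 nM to 600 nM.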

Compound 3, half-maximal inhibitory concentration: 126 nM
Compound 3: middle estimate off by 1.6-fold (0.20 log units), on the high side, and the stated range covers the measured number.
By their numbers in this assay, from the lowest: compounds 1, 3 and 2 (each within the scatter of the next).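

Exchanging the group on this nitrogen now covers a wider range of groups: the open 2-(hydroxysulfamoyl)ethyl chain replaces the four-membered ring group (a 1.7-fold lower number from compound 2 to compound 3 (0.22 log units; within the scatter)) and the amino group (a 1.2-fold higher number from compound 1 to compound 3 (0.07 log units; within the scatter)) in this assay. Going by these compounds alone, the earlier pair covered only one exchange, whereas these steps show that a group with no ring, as well as amino and the ring group, leaves the number within the scatter, so no step at this position yet separates any of the three groups. Nothing measured here explains this lack of separation.

From the compounds shown here alone, whether any group on this nitrogen can move the number beyond the scatter remains open, for example a carboxylic acid or a longer alkyl chain. The compounds shown also leave open whether a plain ethyl group would behave like 2-(hydroxysulfamoyl)ethyl.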